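Chloro to trifluoromethyl on the aryl ring of compound 3

This account rests on a few compounds, and the source may have more. Where it says the series, first, only, none or still open, it means among the compounds named here.

Three measured compounds share one core and differ only in the group on the six-membered aromatic ring of carbon only. In a functional assay on M21 cells (Homo sapiens) for antiproliferative activity, read by sulforhodamine B assay, with a stated time of 48 h (on this read-out lower numbers stand for stronger inhibition of growth and higher numbers for weaker inhibition of growth), compound 1 `Cc1ccc(-c2cc(N3CCC(CNS(N)(=O)=O)CC3)ncn2)cc1` gives 71000 nM. Compound 2 `CCCCc1ccc(-c2cc(N3CCC(CNS(N)(=O)=O)CC3)ncn2)cc1` gives 47200 nM in this assay, and compound 3 `NS(=O)(=O)NCC1CCN(c2cc(-c3ccc(Cl)cc3)ncn2)CC1` gives 50300 nM in this assay. The steps are small throughout: a 1.5-fold lower number from compound 1 to compound 2 (0.18 log units; within the scatter), a 1.4-fold lower number from compound 1 to compound 3 (0.15 log units; within the scatter) and a 1.1-fold higher number from compound 2 to compound 3 (0.03 log units; within the scatter). Compound 3 thus stands within the scatter of both other compounds, nearest to compound 2 and furthest from compound 1, and the numbers support no ordering among the three.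

Compound 4 `NS(=O)(=O)NCC1CCN(c2cc(-c3ccc(C(F)(F)F)cc3)ncn2)CC1` is not yet measured. It differs from compound 3 by trifluoromethyl in place of chloro on an aromatic carbon. Among the measured compounds shown here, the steps that bear on this change are those that alter the same group on the same ring, a 1.4-fold lower number from compound 1 to compound 3 (0.15 log units; within the scatter) and a 1.1-fold higher number from compound 2 to compound 3 (0.03 log units; within the scatter), neither beyond the scatter. With only small swaps of this kind known, no step beyond the scatter is expected in this assay in either direction; the expected step is a 1.0-fold lower number from compound 3 to compound 4 (0.00 log units; within the scatter). Compound 4 is estimated at 50000 nM, with a range from 20000 nM to 125000 nM.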

Compound 4, concentration for 50% growth inhibition: 43100 nM
Beside the measured number, compound 4's estimate is 1.2-fold (0.06 log units) above it; the measured number falls inside the stated range.
By their numbers in this assay, from the lowest: compounds 4, 2, 3 and 1 (each within the scatter of the next).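

In this assay, trifluoromethyl on this aromatic carbon, para to a large group, stays within the scatter of all three earlier groups (a 1.2-fold lower number from compound 3 to compound 4 (0.07 log units; within the scatter)), (a 1.1-fold lower number from compound 2 to compound 4 (0.04 log units; within the scatter)) and (a 1.6-fold lower number from compound 1 to compound 4 (0.22 log units; within the scatter)). This extends the flat picture to a fourth group: methyl, butyl, chloro and trifluoromethyl cannot be ordered here, even though the change from chloro to trifluoromethyl brings more heavy atoms to this position. No measurement shown bears on why these numbers stay so close.

Going by these compounds, whether an amine or a carboxylic acid on this aromatic carbon would move the number beyond the scatter remains open. So does whether a change elsewhere on the shared core would do so.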